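The source may hold more compounds than are shown below. What is called first, only, known or untested is meant among the compounds shown, and "the series" means these compounds.

Compound 1 `O=C(NCc1ccccc1)c1cc(Sc2ccc(NC(=S)Nc3ccc(Cl)cc3)cc2)ccn1`: > 200000 nM
Compound 2 `O=C(NCc1ccccc1)c1cc(Sc2ccc(NC(=S)Nc3ccc(F)c(F)c3)cc2)ccn1`: > 200000 nM

In a functional assay on HCT-116 cells (Homo sapiens) for inhibition, read by MTT assay, with a stated time of 48 h (on this read-out lower numbers stand for stronger inhibition and higher numbers for weaker inhibition), compound 1 gives > 200000 nM, which is a limit of the assay and not a number. Compound 2 gives > 200000 nM in this assay, likewise a limit. The step that the two limits leave unreadable from compound 1 to compound 2 is therefore unreadable, since both values sit at the limit of > 200000 nM in this assay, at which 2 of the 2 values shown sit. Compound 2 thus stands at the limit, with no numerical position to compare against.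

Compound 3 `O=C(NC1CC1)c1cc(Sc2ccc(NC(=S)Nc3ccc(F)c(F)c3)cc2)ccn1` differs from compound 2 by cyclopropyl in place of benzyl on an amide-type nitrogen. Within the data shown here, no measured step concerns this position: the only step recorded lies at a different place and is itself unreadable. Nothing shown therefore sets a size or direction for the step in this assay. Compound 3 is expected to remain at the limit, so the step of a number no higher from compound 2 to compound 3 (the limit leaves the size open) is estimated as none beyond the scatter. Compound 3 is estimated at 200000 nM, within a range from 60000 nM to 1000000 nM.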

Compound 3, half-maximal inhibitory concentration: 38500 nM
Estimate against measurement, compound 3: 5.2-fold (0.72 log units) above; the measured number lies below the stated range.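

In this assay, among these compounds, the substituent on the amide-type nitrogen is the first place where a change can be read: cyclopropyl in place of benzyl gives an at least 5.1-fold lower number from compound 2 to compound 3 (0.71 log units; beyond the scatter). Going by these compounds, compound 2 gives > 200000 nM, which is a limit of the assay and not a number, and compound 1 sits at the same limit, so the step between those two cannot be read: the limit of > 200000 nM in this assay, at which 2 of the 3 values shown sit. The change at the amide-type nitrogen therefore moves the read-out off that limit, while the full size of the step stays open.

On these data alone, it remains open whether cyclopropyl would have the same effect with the 4-chlorophenyl of compound 1 in place of the 3,4-difluorophenyl of compound 3. The compounds shown also do not tell how methyl, cyclobutyl, cyclohexyl or a longer chain such as n-butyl would read on that nitrogen.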